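Inverting the side-chain stereocentres of a sub-nanomolar antiproliferative

The compounds below may be only part of what the source reports. "The series", "measured", "known", "first", "only" and "open" are said of these compounds alone.

Of the compounds shown here, two have been measured in a functional assay on MCF7 cells (Homo sapiens) for antiproliferative activity, read by CellTiter-Glo, with a stated time of 5 days; on this read-out higher numbers stand for weaker inhibition and lower numbers for stronger inhibition. Compound 1, with the structure `CC1=C(c2ccc(O)cc2)C(c2ccc(OC[C@H](C)N3CC[C@@H](C)C3)cc2)Oc2cc(O)ccc21`, gives 0.2 nM in this assay. Compound 2, with the structure `CC1=C(c2cccc(O)c2)[C@H](c2ccc(OC[C@H](C)N3CC[C@@H](C)C3)cc2)Oc2ccc(O)cc21`, gives 0.1 nM in this assay. Compound 2 carries the lower of the two numbers, but its nearest neighbour, compound 1, lies within the usual scatter, so the two cannot be ranked against each other.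

Compound 3, with the structure `CC1=C(c2cccc(O)c2)C(c2ccc(OC[C@@H](C)N3CC[C@H](C)C3)cc2)Oc2ccc(O)cc21`, has not yet been measured. Compared with compound 2 the difference is purely one of drawn configuration: the two compounds have the same atoms and bonds; at least one stereo element is drawn with a configuration in one of them and without one in the other: 3 of 3 stereo elements differ; a stereocentre at a saturated ring carbon is drawn S in compound 2 and without a configuration in compound 3; a stereocentre at a saturated chain carbon is drawn S in compound 2 and R in compound 3; a stereocentre at a saturated ring carbon is drawn R in compound 2 and S in compound 3. Among the measured compounds shown here, no step of this kind has been measured, so the only guide is that both measured compounds are very potent. A modest weakening is expected from compound 2 to compound 3, about a 6.0-fold higher number from compound 2 to compound 3 (0.78 log units; beyond the scatter), and compound 3 is estimated to give 0.6 nM in this assay, plausibly between 0.15 nM and 4 nM.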

Compound 3, half-maximal inhibitory concentration: 0.2 nM
Compound 3: middle estimate off by 3.0-fold (0.48 log units), on the high side; the measured number falls inside the stated range.
By their numbers in this assay, from the lowest: compounds 2, 1 and 3 (each within the scatter of the next).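

Among the compounds shown here, this gives the first readable step between two compounds that have the same atoms and bonds: in this assay, drawing the saturated chain carbon as R rather than S and one saturated ring carbon as S rather than R goes with a 2.0-fold higher number from compound 2 to compound 3 (0.30 log units; within the scatter). Read at face value, these drawn configurations are not shown to separate the two compounds on this read-out. The step is still not a clean inversion of every stereocentre, because a third centre is treated differently in the two drawings: the fact that one of compounds 2 and 3 is drawn with a defined configuration and the other without, at the place where they differ

Going by these compounds, the two side-chain centres changed together, so the contribution of each alone remains open, as does the effect of fixing the undefined ring carbon in compound 3. Also open, on these data alone, is whether either configuration would matter with a piperidine or a dimethylamino group in the side chain.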